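This account rests on a few compounds, and the source may have more. Where it says the series, first, only, none or still open, it means among the compounds named here.

Working notes on the series. In a physicochemical assay for solubility, read by nephelometry, measured as kinetic solubility, at pH 6.5 (a lower number here means a less soluble compound, a higher number a more soluble compound), compound 1 `CN(C)Cc1csc(NC(=O)c2cc(C(C)(C)C)nn2Cc2ccccc2)n1` gives 25 ug/mL, compound 2 `CC(C)(C)c1cc(C(=O)Nc2ccccc2)n(Cc2ccccc2)n1` gives 1.6 ug/mL, and compound 3 `CC(C)(C)c1cc(C(=O)Nc2ccncc2)n(Cc2ccccc2)n1` gives 6.3 ug/mL. Compound 3 therefore holds the middle place of the three numbers. The steps that place it are a 3.9-fold higher number from compound 2 to compound 3 (0.60 log units; beyond the scatter) and a 4.0-fold lower number from compound 1 to compound 3 (0.60 log units; beyond the scatter), both modest, while the largest step in the set is a 16-fold lower number from compound 1 to compound 2 (1.19 log units; beyond the scatter).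

Compound 4 `CC(C)(C)c1cc(C(=O)Nc2cccnc2)n(Cc2ccccc2)n1` has not yet been measured. Its difference from compound 3 is pyridin-3-yl in place of pyridin-4-yl on an amide-type nitrogen, with the same atoms joined differently.

Among the measured compounds shown here, no measured pair compares two pyridinyl groups, so the evidence is indirect. The closest guide is a 3.9-fold higher number from compound 2 to compound 3 (0.60 log units; beyond the scatter), which sets phenyl against pyridin-4-yl. Compound 4 keeps a pyridinyl group on that nitrogen, so its number is expected to lie nearer compound 3 than compound 2, and no step beyond the scatter is expected in this assay. The estimated step is a 1.3-fold lower number from compound 3 to compound 4 (0.10 log units; within the scatter). Compound 4 is estimated at 5 ug/mL, with an expected range of 2.2 ug/mL to 12 ug/mL.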

Compound 4, solubility: 6.3 ug/mL
For compound 4 the middle estimate is 1.3-fold (0.10 log units) below the measured one, within the range that was stated.
By their numbers in this assay, from the lowest: compound 2; then compounds 3 and 4 (each within the scatter of the next); then compound 1.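

Working notes, position on the amide-type nitrogen. In this assay, among the compounds shown here, pyridin-3-yl in place of pyridin-4-yl gives (no change at the digits printed from compound 3 to compound 4 (within the scatter)), so moving the ring nitrogen within the pyridinyl group, with the same atoms joined differently, leaves no step that this read-out can distinguish. The step from phenyl is therefore not particular to pyridin-4-yl, as pyridin-3-yl also shows it (a 3.9-fold higher number from compound 2 to compound 4 (0.60 log units; beyond the scatter)), while the 4-((dimethylamino)methyl)-1,3-thiazol-2-yl group of compound 1 remains apart from both pyridinyl isomers (a 4.0-fold lower number from compound 1 to compound 4 (0.60 log units; beyond the scatter)). Nothing available explains why the two pyridinyl groups read alike in this assay.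

The compounds shown leave open how pyridin-2-yl would read on the same amide-type nitrogen, and whether a dimethylaminomethyl group carried on phenyl or on pyridin-3-yl would bring the number close to that of compound 1. On these data alone, how the step to compound 1 divides between the 1,3-thiazol-2-yl ring and the dimethylamino group also remains open.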